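Changing the Aniline Ring Substituent from Compound 3 to Compound 4

The compounds below may be only part of what the source reports. "The series", "measured", "known", "first", "only" and "open" are said of these compounds alone.

Compound 1 `O=C(CSc1nc(Nc2ccccc2)c2ccccc2n1)Nc1ccccc1F`, compound 2 `O=C(CSc1nc(Nc2ccccc2)c2ccccc2n1)Nc1ccccc1Br`, compound 3 `C=CC(=O)Nc1cccc(NC(=O)CSc2nc(Nc3cccc(Cl)c3)c3ccccc3n2)c1`.

In a functional assay on MDA-MB-231 cells (Homo sapiens) for inhibition, read by MTT assay, with a stated time of 72 h (on this read-out lower numbers stand for stronger inhibition and higher numbers for weaker inhibition), compound 1 gives only a limit, > 50000 nM. In this assay compound 2 gives 14100 nM and compound 3 gives 16300 nM. Compound 3 thus sits beside compound 2 among the two numbers shown, with a gap within the scatter. Within the data shown here, the one measured step, an at least 3.5-fold lower number from compound 1 to compound 2 (0.54 log units; beyond the scatter), concerns the other aromatic ring and does not bear on the change leading to compound 4 `C=CC(=O)Nc1cccc(NC(=O)CSc2nc(Nc3ccc(CC)cc3)c3ccccc3n2)c1`, which is 4-ethylphenyl in place of 3-chlorophenyl on a nitrogen on an aromatic ring. Among the measured compounds shown here, no measured step informs this change, so compound 4 is expected to show no step beyond the scatter, a 1.1-fold lower number from compound 3 to compound 4 (0.04 log units; within the scatter). Compound 4 is therefore estimated at 15000 nM, within 5000 nM to 50000 nM.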

Compound 4, half-maximal inhibitory concentration: 14400 nM
For compound 4 the middle estimate is 1.0-fold (0.02 log units) above the measured one; the measured number falls inside the stated range.
By their numbers in this assay, from the lowest: compounds 2, 4 and 3 (each within the scatter of the next). At a limit, above all of these: compound 1.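

At this position, on a nitrogen on an aromatic ring, 4-ethylphenyl can stand in place of 3-chlorophenyl without a step beyond the scatter: in this assay the change gives a 1.1-fold lower number from compound 3 to compound 4 (0.05 log units; within the scatter). A chlorine-free ring is thus tolerated here, and compound 4 gives a number, while the only limit shown stays with compound 1: the limit of > 50000 nM in this assay, at which 1 of the 4 values shown sits.

The substituent and its place on the ring change together, and these compounds cannot separate the two. Going by these compounds, whether an amine, a carboxylic acid or a chain longer than ethyl on this ring would shift the number remains open.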